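Fluoro Added to the Bromophenyl Ring of Compound 3

This account rests on a few compounds, and the source may have more. Where it says the series, first, only, none or still open, it means among the compounds named here.

Three compounds sharing one core were tested in a functional assay on MCF7 cells (Homo sapiens) for inhibition, read by sulforhodamine B assay, with a stated time of 48 h; a lower number here means a stronger inhibitor of growth, a higher number a weaker inhibitor of growth. Compound 1 `COC(=O)c1sc2cc(Nc3cc(OC)cc(OC)c3)cnc2c1N` gives > 150000 nM, which is a limit of the assay rather than a number. Compound 2 `COC(=O)c1sc2cc(Nc3cc(OC)ccc3Cl)cnc2c1N` gives 22100 nM. Compound 3 `COC(=O)c1sc2cc(Nc3ccccc3Br)cnc2c1N` gives 28900 nM, the higher of the two numbers, though its gap to compound 2 lies within the scatter, so no order between them can be drawn. Compound 4 `COC(=O)c1sc2cc(Nc3ccc(F)cc3Br)cnc2c1N` is not yet measured; it differs from compound 3 by fluoro in place of hydrogen on an aromatic carbon. Within the data shown here, no measured step of this kind exists among the three compounds, so in this assay a change no larger than the scatter is expected, in either direction. The expected step is therefore small, a 1.2-fold lower number from compound 3 to compound 4 (0.06 log units; within the scatter). Compound 4 is estimated at 25000 nM, within 9000 nM to 70000 nM.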

Compound 4, concentration for 50% growth inhibition: 28900 nM
The estimate for compound 4 lay 1.2-fold (0.06 log units) below the measured number; the measured number falls inside the stated range.
By their numbers in this assay, from the lowest: compounds 2, 3 and 4 (each within the scatter of the next). At a limit, above all of these: compound 1.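

In this assay, among these compounds, the only measured step at this position shows no change at the digits printed from compound 3 to compound 4 (within the scatter), with fluoro in place of hydrogen on an aromatic carbon, meta to a bromo group and para to a large group. At this position, in this one pair, the single added fluorine atom leaves the number within the scatter. Nothing measured here bears on why the step is this small.

Going by these compounds, it remains open whether an amine, a carboxylic acid or a longer chain at this position would also leave the number within the scatter. On these data alone, whether fluoro would do the same without the bromo group also stays open.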